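The source may report more compounds than this note shows. Statements on the series, on what has been measured and on what is new or still open speak of the compounds shown alone.

In an in vitro assay on SH-SY5Y cells for displacement of a labelled ligand from Neuronal acetylcholine receptor; alpha3/beta4 (Homo sapiens) (a lower number here means a stronger inhibitor, a higher number a weaker inhibitor), compound 1 `Clc1ccc(C2=CC3CNCC(C2)C3)cn1` gives 6.2 nM. Within the data shown here, the only other measured compound, compound 2 `COc1cc(C2=CC3CNCC(C2)C3)cnc1Cl`, gives 7 nM in this assay; the step of a 1.1-fold higher number from compound 1 to compound 2 (0.05 log units; within the scatter) stays within the scatter, so the two numbers cannot be told apart. Compound 3 `C1=C(c2ccc(-c3ccccc3)nc2)CC2CNCC1C2` differs from compound 1 by phenyl in place of chloro on an aromatic carbon. Among the measured compounds shown here, no measured step alters the aromatic carbon next to the ring nitrogen, and the one measured step, a methoxy added elsewhere, moved nothing beyond the scatter, so it offers no guide. For the measured compounds named here, with a change this large and no precedent, the estimate for compound 3 is 20 nM, with a range from 4 nM to 100 nM, meaning an expected step of a 3.2-fold higher number from compound 1 to compound 3 (0.51 log units; beyond the scatter).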

Compound 3, inhibition constant: 507 nM
For compound 3 the middle estimate is 25-fold (1.40 log units) below the measured one; the measured number lies above the stated range.
By their numbers in this assay, from the lowest: compounds 1 and 2 (each within the scatter of the next); then compound 3.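

In this assay, the aromatic carbon next to the ring nitrogen proves sensitive to what it carries: phenyl in place of chloro gives an 82-fold higher number from compound 1 to compound 3 (1.91 log units; beyond the scatter). Among these compounds, the earlier methoxy change, made at another ring carbon, gave only a 1.1-fold higher number from compound 1 to compound 2 (0.05 log units; within the scatter), so this is the first measured sign that a substituent on this ring can matter. Nothing measured here explains the loss.

The compounds shown leave open whether any group other than chloro brings such a loss. A methyl or an amine at this carbon could fall anywhere relative to chloro and phenyl.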